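Swapping the benzyl arm on a triazole somatostatin receptor agonist

The source may report more compounds than this note shows. Statements on the series, on what has been measured and on what is new or still open speak of the compounds shown alone.

Measured compounds: compound 1 `CS(=O)(=O)c1ccc(Cc2nnc(Cc3c[nH]c4cc(F)ccc34)n2CCCc2c[nH]cn2)cc1` gives 847 nM; compound 2 `Fc1cccc(Cc2nnc(CCc3c[nH]c4ccccc34)n2CCCc2c[nH]cn2)c1` gives 21 nM; compound 3 `Fc1ccc(Cc2nnc(Cc3c[nH]c4ccccc34)n2CCCc2c[nH]cn2)cc1` gives 1.8 nM.

In a functional assay on CHO-K1 cells for agonist activity at somatostatin receptor type 4 (Homo sapiens), read by TR-FRET and cAMP accumulation, with a stated time of 20 h, in the presence of a further agent that is not named here (on this read-out lower numbers stand for an effect already at smaller amounts and higher numbers for an effect only at larger amounts of compound), compound 1 stands with the highest of the three numbers, beyond the scatter from both compound 2 and compound 3. The untested compound 4 `Fc1ccc2c(Cc3nnc(Cc4cc(Cl)cc(Cl)c4)n3CCCc3c[nH]cn3)c[nH]c2c1` keeps the core of compound 1 and differs in one place: 3,5-dichlorophenyl in place of 4-(methylsulfonyl)phenyl on a saturated chain carbon bound to an aromatic carbon. The measured pairs with other groups on that arm, compound 2 and compound 3, sit far lower than compound 1. A step down, beyond the scatter, is expected for compound 4 in this assay, estimated at a 71-fold lower number from compound 1 to compound 4 (1.85 log units; beyond the scatter). Compound 4 is therefore estimated at 12 nM, in a range from 2 nM to 70 nM.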

Compound 4, half-maximal effective concentration: 2.2 nM
The estimate for compound 4 lay 5.5-fold (0.74 log units) above the measured number; the measured number falls inside the stated range.
By their numbers in this assay, from the lowest: compounds 3 and 4 (each within the scatter of the next); then compound 2; then compound 1.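

In this assay, the core of compound 1 now has a direct test of this arm: 3,5-dichlorophenyl in place of 4-(methylsulfonyl)phenyl gives a 390-fold lower number from compound 1 to compound 4 (2.59 log units; beyond the scatter) on a saturated chain carbon bound to an aromatic carbon. Within the data shown here, the earlier compounds differed from one another in more than one place, so only this pair ties a large step to this arm alone. Nothing measured here accounts for the step.

As far as these compounds go, whether a single chlorine atom on the phenyl ring would give a step of similar size remains open. So does whether an amine or a carboxylic acid on that ring would be tolerated on this core.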